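A few compounds are considered here, and "the series" means these few. Any claim that something is new, unique, unknown or untested is made for them only; others in the source may bear on it.

Of the compounds shown here, three that share one core have been measured in an assay for binding affinity to adenosine receptor A1 (Bos taurus); a lower number here means a stronger inhibitor, a higher number a weaker inhibitor. Compound 1 `CCCn1c(=O)c2nc(-c3ccc(S(=O)(=O)NCCCC(=O)OCC)cc3)[nH]c2n(CCC)c1=O` gives 0.24 nM, compound 2 `CN(C)c1cccc(-c2nc3c(=O)n(C)c(=O)n(C)c3[nH]2)c1` gives 80 nM, and compound 3 `Cn1c(=O)c2nc(-c3ccc([N+](=O)[O-])cc3)[nH]c2n(C)c1=O` gives 8 nM. Compound 3 thus stands second highest of the three numbers: its nearest neighbour is compound 2, whose higher number lies beyond the scatter, and furthest away is compound 1, whose lower number also lies beyond the scatter. Compound 4 `CCOc1ccc(-c2nc3c(=O)n(C)c(=O)n(C)c3[nH]2)cc1` differs from compound 3 in one place: ethoxy in place of nitro on an aromatic carbon. Going by the values given here, no measured pair shows this change, so its size cannot be read from the data. In this assay the expected step of a 3.8-fold higher number from compound 3 to compound 4 (0.57 log units; beyond the scatter) is a modest rise, beyond the scatter but uncertain. Compound 4 is estimated at 30 nM, within a range from 8 nM to 120 nM.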

Compound 4, half-maximal inhibitory concentration: 2 nM
For compound 4 the middle estimate is 15-fold (1.18 log units) above the measured one; the whole stated range lies above it.
By their numbers in this assay, from the lowest: compound 1; then compound 4; then compound 3; then compound 2.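

In this assay the swap of nitro for ethoxy on this aromatic carbon, para to a large group, gives a 4.0-fold lower number from compound 3 to compound 4 (0.60 log units; beyond the scatter) and is the first one-place comparison among these compounds. Both groups have 3 heavy atoms, so the number moves beyond the scatter with no change in that count. No measurement shown gives a reason for this step. As far as these compounds go, how an amine, a carboxylic acid or a longer chain on the same carbon would shift the number remains open. From the compounds shown here alone, whether this swap gives a similar step on another core also remains open.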